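N-Methylation of a Boronic Acid Anilide Series

A few compounds are considered here, and "the series" means these few. Any claim that something is new, unique, unknown or untested is made for them only; others in the source may bear on it.

Measured compounds:
compound 1 `O=C(Nc1ccc(F)cc1)c1ccc(NCc2cccc(B(O)O)c2)nc1` 611 nM
compound 2 `CN(Cc1cccc(B(O)O)c1)c1ccc(C(=O)Nc2ccc(F)cc2)cn1` 4100 nM
compound 3 `O=C(Nc1ccc(F)cc1)c1cnc(NCc2cccc(B(O)O)c2)nc1` 1340 nM

In a functional assay on RBL cells for antagonist activity at C-X-C chemokine receptor type 1 (Homo sapiens), read by fluorescence and calcium flux, with a stated time of 30 min (a higher number here means a weaker inhibitor, a lower number a stronger inhibitor), compound 3 stands second highest of the three numbers, between compound 1 and compound 2. Compound 4 `CN(Cc1cccc(B(O)O)c1)c1ncc(C(=O)Nc2ccc(F)cc2)cn1` differs from compound 3 in one place: methyl in place of hydrogen on a nitrogen on an aromatic ring. For the measured compounds named here, the one measured step that bears on this change is the same exchange on the core of compound 1, which gave a 6.7-fold higher number from compound 1 to compound 2 (0.83 log units; beyond the scatter). A rise of comparable size is therefore expected for compound 4 in this assay, estimated as a 5.2-fold higher number from compound 3 to compound 4 (0.72 log units; beyond the scatter). Compound 4 is expected to give about 7000 nM, with a likely range from 2500 nM to 20000 nM.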

Compound 4, half-maximal inhibitory concentration: 2500 nM
Compound 4: the middle estimate sits 2.8-fold (0.45 log units) above what was measured, and the stated range covers the measured number.
By their numbers in this assay, from the lowest: compound 1; then compounds 3, 4 and 2 (each within the scatter of the next, the first and the last beyond it).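

Methyl in place of hydrogen on this nitrogen does not always give a step beyond the scatter in this assay: here it gives a 1.9-fold higher number from compound 3 to compound 4 (0.27 log units; within the scatter). The earlier pair alone could not show that the size of this change depends on the core that carries it, and the two steps now differ by more than the scatter: the same change on two cores in this assay, a 6.7-fold higher number (0.83 log units; beyond the scatter) from compound 1 to compound 2 and a 1.9-fold higher number (0.27 log units; within the scatter) from compound 3 to compound 4, 3.6-fold (0.56 log units) apart, beyond the scatter of two such steps

The compounds shown leave open whether a longer chain, such as ethyl, or an amine-bearing chain on this nitrogen would behave the same way on both cores. They also do not show why the two cores respond differently.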